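Fluoro Added to the Bromophenyl Ring of Compound 2

A few compounds are considered here, and "the series" means these few. Any claim that something is new, unique, unknown or untested is made for them only; others in the source may bear on it.

Compound 2 `Cn1ccc2c(Oc3ccc(NC(=O)c4cc5cccnc5n(-c5ccc(Br)cc5)c4=O)cc3F)ccnc21` stands highest of the two numbers in a functional assay on HT-29 cells (Homo sapiens) for antiproliferative activity, read by MTT assay, with a stated time of 72 h; on this read-out higher numbers stand for weaker inhibition and lower numbers for stronger inhibition; its nearest neighbour is compound 1 `Cn1ccc2c(Oc3ccc(NC(=O)c4cc5cccnc5n(-c5ccc(Cl)cc5)c4=O)cc3F)ccnc21`, and the step between them is a 1.5-fold higher number from compound 1 to compound 2 (0.18 log units; within the scatter). In this assay compound 1 gives 220 nM and compound 2 gives 330 nM. The next compound, compound 3 `Cn1ccc2c(Oc3ccc(NC(=O)c4cc5cccnc5n(-c5ccc(Br)cc5F)c4=O)cc3F)ccnc21`, is not yet measured. The change from compound 2 to compound 3 is fluoro in place of hydrogen on an aromatic carbon, so that a 4-bromophenyl becomes a 4-bromo-2-fluorophenyl. Within the data shown here, the only measured step, chloro to bromo, does not involve this kind of change and was itself within the scatter, so nothing measured points to a sizeable move in either direction. The expected step from compound 2 to compound 3 is therefore no change at the digits printed from compound 2 to compound 3 (within the scatter), not beyond the scatter. The estimated value for compound 3 in this assay is 330 nM, with a range from 120 nM to 900 nM.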

Compound 3, half-maximal inhibitory concentration: 3290 nM
Compound 3: the middle estimate sits 10-fold (1.00 log units) below what was measured; measured number above the stated range.
By their numbers in this assay, from the lowest: compounds 1 and 2 (each within the scatter of the next); then compound 3.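

Replacing chloro with bromo had left the number within the scatter, but in this assay the change from 4-bromophenyl to 4-bromo-2-fluorophenyl gives a 10-fold higher number from compound 2 to compound 3 (1.00 log units; beyond the scatter) and shows that this ring does not tolerate every small change. One added fluorine atom, ortho to a large group, is enough to weaken the antiproliferative effect clearly. The comparison with the chloro compound points the same way, with a 15-fold higher number from compound 1 to compound 3 (1.17 log units; beyond the scatter) as the larger gap, while no available information explains the loss.

Going by these compounds, whether the loss belongs to fluoro itself or would follow any group at this place remains open, and a methyl or a methoxy group there would help to separate the two. Also open, on these data alone, is whether fluoro would have the same effect on the 4-chlorophenyl ring of compound 1.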